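Cyclohexyl to ethyl on the amide-type nitrogen: half-life notes

A few compounds are considered here, and "the series" means these few. Any claim that something is new, unique, unknown or untested is made for them only; others in the source may bear on it.

Measured in an in vitro ADME assay on the whole organism (small intestine) for pharmacokinetics, with Rattus norvegicus as the target; on this read-out higher numbers stand for a longer-lived compound and lower numbers for a shorter-lived compound:
- compound 1 `CCOC(=O)CN(C(=O)/C(C)=C/c1ccc(C(=O)Oc2ccc(C(=N)N)cc2)cc1)C1CCCC1`: > 1 h (a limit)
- compound 2 `C/C(=C\c1ccc(C(=O)Oc2ccc(C(=N)N)cc2)cc1)C(=O)N(CC(=O)O)C1CCCCC1`: 0.817 h
- compound 3 `C=CCN(CCCC(=O)OCC)C(=O)/C(C)=C/c1ccc(C(=O)Oc2ccc(C(=N)N)cc2)cc1`: 1 h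

Compound 2 gives 0.817 h, within the scatter of compound 3 at 1 h. The value of compound 1, > 1 h, is a limit. Unmeasured compound 4 `CCN(CC(=O)O)C(=O)/C(C)=C/c1ccc(C(=O)Oc2ccc(C(=N)N)cc2)cc1` has ethyl in place of cyclohexyl on an amide-type nitrogen. Among the compounds with values here, no measured pair isolates this change. Within the data shown here, the expectation therefore rests on compound 2 at 0.817 h, the only measured compound carrying carboxymethyl. No change beyond the scatter is expected, in either direction: the expected step is a 1.0-fold lower number from compound 2 to compound 4 (0.01 log units; within the scatter). For compound 4 the estimated half-life is 0.8 h, with an expected range from 0.4 h to 1.6 h.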

Compound 4, half-life: > 1 h
Compound 4: a limit, no number; the forecaster's own chance of this, stated with the estimate: 20%; middle value at least 1.2-fold (0.09 log units) from the limit.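

In this assay compound 4 gives > 1 h, which is a limit and not a number. Ethyl in place of cyclohexyl on the amide-type nitrogen, with carboxymethyl kept, can now be read as a single change, and it gives an at least 1.2-fold higher number from compound 2 to compound 4 (0.08 log units; that floor lies within the scatter). Only a floor is known for this step, with no upper bound: the limit of > 1 h in this assay, at which 2 of the 4 values shown sit.

Still open, from the compounds shown here alone, is how a longer chain such as butyl on this nitrogen would read. Also open, going by these compounds, is how ethyl would read with a primary amide in place of the carboxylic acid of carboxymethyl.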